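Varying the benzylsulfanyl group of compound 1

The source may report more compounds than this note shows. Statements on the series, on what has been measured and on what is new or still open speak of the compounds shown alone.

Compound 1 `Cc1ccc(CSc2nc3nc(C)cc(Nc4ccc(C(=O)/C=C/c5ccc6ccccc6c5)cc4)n3n2)cc1`: 880 nM
Compound 2 `Cc1cc(Nc2ccc(C(=O)/C=C/c3ccc4ccccc4c3)cc2)n2nc(SCc3ccc([N+](=O)[O-])cc3)nc2n1`: 1130 nM
Compound 3 `Cc1cc(Nc2ccc(C(=O)/C=C/c3ccc4ccccc4c3)cc2)n2nc(SCc3ccccc3C(F)(F)F)nc2n1`: 1240 nM

In a functional assay on SW-620 cells (Homo sapiens) for cytotoxicity, read by MTT assay, with stated times of 4 h and 72 h, tested at 5 uM (on this read-out lower numbers stand for stronger inhibition and higher numbers for weaker inhibition), compound 1 gives the lowest of the three numbers, yet its steps to the others are small: a 1.3-fold higher number from compound 1 to compound 2 (0.11 log units; within the scatter) and a 1.4-fold higher number from compound 1 to compound 3 (0.15 log units; within the scatter), both within the scatter, as is a 1.1-fold higher number from compound 2 to compound 3 (0.04 log units; within the scatter). Compound 4 `Cc1cc(Nc2ccc(C(=O)/C=C/c3ccc4ccccc4c3)cc2)n2nc(SCc3ccccc3Br)nc2n1` differs from compound 1 in one place: 2-bromophenyl in place of 4-methylphenyl on a saturated chain carbon bound to a sulfur. The step that bears most on it is the one that also removes the 4-methylphenyl group, a 1.4-fold higher number from compound 1 to compound 3 (0.15 log units; within the scatter), which stayed within the scatter, and the remaining steps point the same way. No shift beyond the scatter is therefore expected for compound 4 in this assay; its value is estimated at 1050 nM (range 550 nM to 2000 nM), that is a 1.2-fold higher number from compound 1 to compound 4 (0.08 log units; within the scatter).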

Compound 4, half-maximal inhibitory concentration: 420 nM
For compound 4 the middle estimate is 2.5-fold (0.40 log units) above the measured one; measured number outside the range, below it.
By their numbers in this assay, from the lowest: compound 4; then compounds 1, 2 and 3 (each within the scatter of the next).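

The saturated chain carbon bound to a sulfur proved able to move the number beyond the scatter in this assay, which no earlier change there had done, with a 2.1-fold lower number from compound 1 to compound 4 (0.32 log units; beyond the scatter) and a 2.7-fold lower number from compound 2 to compound 4 (0.43 log units; beyond the scatter) for the 2-bromophenyl group. Even bromo in place of trifluoromethyl on an aromatic carbon counts, with a 3.0-fold lower number from compound 3 to compound 4 (0.47 log units; beyond the scatter) from that single swap, so the steps here are modest but real. Nothing measured here accounts for this shift. The compounds shown leave open whether 4-bromophenyl on the same carbon would behave like 2-bromophenyl, and how 2-chlorophenyl or 2-aminophenyl would read there.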